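The source may hold more compounds than are shown below. What is called first, only, known or untested is meant among the compounds shown, and "the series" means these compounds.

Compound 1, `Nc1ccccc1NC(=O)c1ccc(Cn2cnc3c(Nc4ccccc4)nc(Cl)nc32)cc1`, gives 49.6%
Compound 2, `Cc1ccc(Nc2nc(Cl)nc3c2ncn3Cc2ccc(/C=C/C(=O)Nc3ccccc3N)cc2)cc1`, gives 33.6%
Compound 3, `CC(C)n1cnc2c(Nc3cccc(Cl)c3)nc(NCOCc3ccc(C(=O)Nc4ccccc4N)cc3)nc21`, gives 1.48%

These numbers come from a functional assay on HepG2 cells (Homo sapiens) for antiproliferative activity, read by CCK-8 assay, with a stated time of 72 h, tested at 2 uM; on this read-out lower numbers stand for a weaker effect and higher numbers for a stronger effect at the one concentration tested. Compound 1 stands highest of the three; compound 2 lies lower by a gap beyond the scatter, and compound 3 lower still, also beyond the scatter. Compound 4, `Nc1ccccc1NC(=O)c1ccc(Cn2cnc3c(Nc4ccc(-c5ccccn5)cc4)nc(Cl)nc32)cc1`, has not yet been measured. It differs from compound 1 in one place: pyridin-2-yl in place of hydrogen on an aromatic carbon. Among the compounds with values here, no pair of measured compounds differs in just one place, so no step of this kind has been seen. The step of a number 2.6 percentage points lower from compound 1 to compound 4 (within the scatter) is expected to be small, within the scatter. Compound 4 is therefore expected to give about 47%, between 22% and 72%.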

Compound 4, a percentage reported as inhibition, at one concentration (the size of the read-out at that concentration, not a potency): 11.5%
Estimate against measurement, compound 4: 35.5 percentage points above; measured number outside the range, below it.
By their numbers in this assay, from the lowest: compounds 3 and 4 (each within the scatter of the next); then compound 2; then compound 1.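

In this assay, a number 38.1 percentage points lower from compound 1 to compound 4 (beyond the scatter) is what adding pyridin-2-yl to the phenyl ring costs, on a carbon para to a large group. This shows that the position is not indifferent to what it carries: this one added ring is enough to change the read-out by a large step on an otherwise unchanged compound. No measurement here explains the drop. As far as these compounds go, whether the loss comes from the added ring as a whole or from its nitrogen stays open, as does how a methoxy group or an amine would fare on the same carbon.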